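The source may hold more compounds than are shown below. What is called first, only, known or untested is meant among the compounds shown, and "the series" means these compounds.

Compound 1 `COc1ccc2c(c1)[C@@H](O)CN(C)C2` gives > 100000 nM, a limit.
Compound 2 `Cc1ccccc1COc1ccc2c(c1)[C@@H](O)CN(C)C2` gives > 100000 nM, a limit.
Compound 3 `CN1Cc2ccc(OCC3CCNCC3)cc2[C@@H](O)C1` gives > 100000 nM, a limit.

Among the measured compounds shown here, in an ADME assay on Vero cells (Chlorocebus sabaeus) for cytotoxicity, read by sulforhodamine B assay, with a stated time of 72 h (a lower number here means a stronger inhibitor, a higher number a weaker inhibitor), every value so far is a limit and not a number, so compound 3 stands exactly where the others stand, at the limit of > 100000 nM in this assay, at which 3 of the 3 values shown sit. Compound 4 `CN1Cc2ccc(OCc3cccc(Br)c3)cc2[C@@H](O)C1` awaits measurement; it differs from compound 3 by 3-bromophenyl in place of piperidin-4-yl on a saturated chain carbon bound to an oxygen on an aromatic ring. The measured steps at the same place, a step that the two limits leave unreadable from compound 1 to compound 2, a step that the two limits leave unreadable from compound 1 to compound 3 and a step that the two limits leave unreadable from compound 2 to compound 3, are all unreadable between limits, so no direction and no size can be read for the step now in question. For compound 4 the value is expected to sit again at the limit, estimated at 150000 nM, within 40000 nM to 500000 nM. The step this estimate means, a step that the limit leaves unreadable from compound 3 to compound 4, is expected to stay unreadable, with no change beyond the scatter.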

Compound 4, half-maximal inhibitory concentration: 60300 nM
The estimate for compound 4 lay 2.5-fold (0.40 log units) above the measured number; the measured number falls inside the stated range.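

In this assay, among the compounds shown here, 3-bromophenyl on the saturated chain carbon bound to an oxygen on an aromatic ring gives the only number so far rather than a limit, with an at least 1.6-fold lower number from compound 3 to compound 4 (0.21 log units; that floor lies within the scatter), an at least 1.6-fold lower number from compound 2 to compound 4 (0.21 log units; that floor lies within the scatter) and an at least 1.6-fold lower number from compound 1 to compound 4 (0.21 log units; that floor lies within the scatter). All three floors lie within the scatter, so this change at this position shows a measurable read-out but no established separation from the other compounds. The remaining values are limits, and the steps among them cannot be read: the limit of > 100000 nM in this assay, at which 3 of the 4 values shown sit.

Still open, from the compounds shown here alone, is how far a carboxylic acid or an amine in place of the bromine, or a longer chain at the same place, would move the number. Going by these compounds, the true distance of compound 4 from the other compounds also remains unknown.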